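A few compounds are considered here, and "the series" means these few. Any claim that something is new, unique, unknown or untested is made for them only; others in the source may bear on it.

Measured so far in this series:
compound 1 `Cc1noc(C)c1-c1cnc(N)c(Oc2ccc(C(=O)Nc3ccc(Cl)cc3)cc2)n1`: 14400 nM
compound 2 `Cn1cc(-c2cnc(N)c(Oc3ccc(C(=O)Nc4ccc(Cl)cc4)cc3)n2)cn1`: 11900 nM
compound 3 `Cc1noc(C)c1-c1cnc(N)c(NCc2ccc(C(=O)Nc3ccc(Cl)cc3)cc2)n1`: > 100000 nM

The entry for compound 3 is a limit of the assay, not a number (the limit of > 100000 nM in this assay, at which 1 of the 3 values shown sits).

In a functional assay on HepG2 cells (Homo sapiens) for inhibition, read by MTT assay, with a stated time of 72 h (a higher number here means a weaker inhibitor, a lower number a stronger inhibitor), compound 1 and compound 2 differ only by 1-methyl-1H-pyrazol-4-yl in place of 3,5-dimethyl-1,2-oxazol-4-yl on an aromatic carbon, and the step is a 1.2-fold lower number from compound 1 to compound 2 (0.08 log units; within the scatter). The difference between the core of compound 1 and the core of compound 3 is not broken down here. Compound 4 `Cn1cc(-c2cnc(N)c(NCc3ccc(C(=O)Nc4ccc(Cl)cc4)cc3)n2)cn1` carries the same change on the core of compound 3, namely (1-methyl-1H-pyrazol-4-yl in place of 3,5-dimethyl-1,2-oxazol-4-yl on an aromatic carbon), with the place described in identical words.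

For compound 4 in this assay the expected step is a step that the limit leaves unreadable from compound 3 to compound 4. This rests on the step of a 1.2-fold lower number from compound 1 to compound 2 (0.08 log units; within the scatter), which lies within the scatter, so the change is not expected to move compound 4 off the limit. Compound 4 is estimated at 150000 nM, most likely reported again as a limit, between 40000 nM and 500000 nM.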

Compound 4, half-maximal inhibitory concentration: 20100 nM
Compound 4: middle estimate off by 7.5-fold (0.87 log units), on the high side; measured number below the stated range.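

In this assay the change from 3,5-dimethyl-1,2-oxazol-4-yl to 1-methyl-1H-pyrazol-4-yl does not carry over between the two cores with the same size: the same change on two cores in this assay, a 1.2-fold lower number (0.08 log units; within the scatter) from compound 1 to compound 2 and an at least 4.9-fold lower number (0.69 log units; beyond the scatter) from compound 3 to compound 4, at least 4.1-fold (0.61 log units) apart, beyond the scatter of two such steps.
The step on the second core is an at least 4.9-fold lower number from compound 3 to compound 4 (0.69 log units; beyond the scatter) and gives only a lower bound on the size, since its starting value is a limit of the assay: the limit of > 100000 nM in this assay, at which 1 of the 4 values shown sits.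
These two cores show that the step depends on the core in this pair, but they do not show why, nor that this holds for any other core.

On these data alone, whether an unsubstituted phenyl or a pyridin-3-yl on that aromatic carbon follows the same dependence on the core stays open. So does the effect of a longer chain in place of the link that separates the two cores.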